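Swapping a pyrazole for an oxazole on a shared core

This account rests on a few compounds, and the source may have more. Where it says the series, first, only, none or still open, it means among the compounds named here.

Of the compounds shown here, three sharing one core have been tested. Compound 1 `Cc1n[nH]cc1-c1cccc2c1CCC2c1ncc[nH]1` carries a 3-methyl-1H-pyrazol-4-yl group and is the strongest of the three in a functional assay on CHO cells for agonist activity at Alpha-1A adrenergic receptor (Homo sapiens), read by FLIPR and calcium flux (on this read-out higher numbers stand for larger maximal responses and lower numbers for smaller maximal responses), where compound 1 gives 91%. Compound 2 `COc1cccc2c1CCC2c1ncc[nH]1`, with a methoxy group at the same position, gives 65%, and compound 3 `c1ccc2c(c1)CCC2c1ncc[nH]1`, with only a hydrogen there, gives 54%. The steps are all beyond the scatter: a number 26 percentage points lower from compound 1 to compound 2 (beyond the scatter), a number 37 percentage points lower from compound 1 to compound 3 (beyond the scatter) and a number 11 percentage points lower from compound 2 to compound 3 (beyond the scatter). So on these numbers the pyrazolyl group matters most, and even a methoxy group beats a bare hydrogen.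

Compound 4 `c1cc(-c2ncco2)c2c(c1)C(c1ncc[nH]1)CC2` changes this position once more: 1,3-oxazol-2-yl in place of 3-methyl-1H-pyrazol-4-yl on an aromatic carbon. Both steps away from compound 1 bear on this change, since each removes the pyrazolyl group, and both lowered the response. Here, however, a five-membered aromatic ring stays in place, which neither compound 2 nor compound 3 offers, so the loss is expected to be smaller than a number 26 percentage points lower from compound 1 to compound 2 (beyond the scatter). The expected step is a number 15 percentage points lower from compound 1 to compound 4 (beyond the scatter), a modest decrease. For compound 4 the estimate in this assay is 76%, with a likely range from 58% to 94%.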

Compound 4, largest response reached (Emax), in percent of the reference or control that the assay uses: 63%
The estimate for compound 4 lay 13 percentage points above the measured number; the range from low to high includes it.
By their numbers in this assay, from the lowest: compounds 3, 4 and 2 (each within the scatter of the next, the first and the last beyond it); then compound 1.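

The pyrazolyl group cannot simply be exchanged for another five-membered aromatic ring with 2 hetero atoms: in this assay, 1,3-oxazol-2-yl in place of 3-methyl-1H-pyrazol-4-yl gives a number 28 percentage points lower from compound 1 to compound 4 (beyond the scatter) and costs about as much of the response as methoxy did. The oxazolyl group also does not stand apart from the smaller groups, with a number 2 percentage points lower from compound 2 to compound 4 (within the scatter) and a number 9 percentage points higher from compound 3 to compound 4 (within the scatter), so a ring at this position does not by itself give a larger response than methoxy or hydrogen. The group that leaves has 1 hydrogen-bond donor and the group that enters has 0, and they also differ in heavy atoms and hetero atoms, but nothing available ties the drop to any one of these differences.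

From the compounds shown here alone, it remains open whether the high response of compound 1 depends on the ring's hydrogen-bond donor or on its methyl group, a question that a plain 1H-pyrazol-4-yl group, lacking the methyl, would help to address. How a group without a ring, such as an amine or a carboxylic acid, would behave on this aromatic carbon is also unknown.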